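The source may hold more compounds than are shown below. What is called first, only, known or untested is meant among the compounds shown, and "the series" means these compounds.

In a functional assay on MV4-11 cells (Homo sapiens) for cytotoxicity, read by MTT assay, with a stated time of 72 h (on this read-out lower numbers stand for stronger inhibition and higher numbers for weaker inhibition), compound 1 `CCOC(=O)c1csc2nc(-c3ccc(NC(=O)Nc4ccc(Br)cn4)cc3)cn12` gives 2440 nM, while compound 2 `CCOC(=O)c1csc2nc(-c3ccc(NC(=O)CCl)cc3)cn12` gives 9070 nM, the higher of the two numbers and so the weaker inhibition. The two share a core and differ only in the group on the carbonyl carbon. Compound 3 `C=CC(=O)Nc1ccc(-c2cn3c(C(=O)OCC)csc3n2)cc1` alters compound 2 at that same carbon: vinyl in place of chloromethyl on a carbonyl carbon, with vinyl in place of chloromethyl. Going by the values given here, the one measured step, a 3.7-fold higher number from compound 1 to compound 2 (0.57 log units; beyond the scatter), is modest and touches the same carbon, but it involves a (5-bromopyridin-2-yl)amino group, which plays no part in the new change. Among the compounds with values here, no measured pair compares vinyl with chloromethyl. The expected result is therefore no clear shift in either direction, with an estimated 1.1-fold lower number from compound 2 to compound 3 (0.05 log units; within the scatter) that stays within the usual scatter. The estimated value for compound 3 is 8000 nM, with an expected range of 2800 nM to 23000 nM.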

Compound 3, half-maximal inhibitory concentration: 2930 nM
Estimate against measurement, compound 3: 2.7-fold (0.44 log units) above; the range from low to high includes it.
By their numbers in this assay, from the lowest: compounds 1 and 3 (each within the scatter of the next); then compound 2.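

In this assay, vinyl in place of chloromethyl on the carbonyl carbon gives a 3.1-fold lower number from compound 2 to compound 3 (0.49 log units; beyond the scatter), so this position responds to an exchange between two groups of equal heavy-atom count, and not only to a change involving the (5-bromopyridin-2-yl)amino group. Vinyl in place of that group gives a 1.2-fold higher number from compound 1 to compound 3 (0.08 log units; within the scatter), which lies within the scatter, so two quite different groups on this carbon give readings that cannot be told apart in this assay. Nothing available here gives a reason for the difference between vinyl and chloromethyl.

On these data alone, it remains open whether an ethyl group or a simple amine on this carbonyl carbon would read closer to compound 2 or to compound 3. All three compounds share one core, so whether the vinyl-for-chloromethyl step holds on a different core is also unknown.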